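A few compounds are considered here, and "the series" means these few. Any claim that something is new, unique, unknown or untested is made for them only; others in the source may bear on it.

In a functional assay on G-361 cells (Homo sapiens) for antiproliferative activity, with a stated time of 72 h (a lower number here means a stronger inhibitor, a higher number a weaker inhibitor), three compounds sharing a core have been measured. Compound 1 `OC[C@H]1O[C@@H](n2cnc3c(NCc4ccc(F)cc4)ncnc32)[C@H](O)[C@@H]1O` gives > 166000 nM, a limit of the assay. Compound 2 `OC[C@H]1O[C@@H](n2cnc3c(NCc4ccc(Cl)cc4)ncnc32)[C@H](O)[C@@H]1O` gives > 166000 nM, also a limit. Compound 3 `COc1ccccc1CNc1ncnc2c1ncn2[C@@H]1O[C@H](CO)[C@@H](O)[C@H]1O` gives > 166000 nM, again a limit. Compound 2 therefore has no numerical value, only a limit shared with the other two. Compound 4 `OC[C@H]1O[C@@H](n2cnc3c(NCc4ccc(OC(F)(F)F)cc4)ncnc32)[C@H](O)[C@@H]1O` has trifluoromethoxy in place of chloro on an aromatic carbon, para to a large group: trifluoromethoxy in place of chloro on an aromatic carbon. The closest measured change is a step that the two limits leave unreadable from compound 1 to compound 2, and the other is a step that the two limits leave unreadable from compound 2 to compound 3; neither has a readable size. The expectation for compound 4 rests on (the limit of > 166000 nM in this assay, at which 3 of the 3 values shown sit), so no clear change in either direction is expected. The expected step is a number no higher from compound 2 to compound 4 (the limit leaves the size open). Compound 4 is estimated at 166000 nM, with an expected range from 40000 nM to 200000 nM.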

Compound 4, half-maximal inhibitory concentration: > 166000 nM
Compound 4 gave a limit, no number (the forecaster's own chance of this, stated with the estimate: 75%); the middle value sits exactly at the limit.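

The steps from compound 1 and from compound 2 to compound 4 cannot be read, because each compound gave only a limit: the limit of > 166000 nM in this assay, at which 4 of the 4 values shown sit. The compounds shown leave open whether any of these group changes alters activity in this assay; none has a numerical value.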